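The source may report more compounds than this note shows. Statements on the series, on what has been measured and on what is new or still open speak of the compounds shown alone.

Among the compounds with values here, compound 1 `CCCCN(CC)c1nc(C)nc2c1NCCN2c1ccc(OC)cc1C` is one of two compounds measured in an assay on frontal cortex for displacement of a labelled ligand from corticotropin-releasing factor receptor 1 (Rattus norvegicus); a lower number here means a stronger inhibitor, a higher number a weaker inhibitor. In this assay compound 1 gives 11.7 nM, the higher of the two numbers; compound 2 `CCCCN(CC)c1cc(C)nc2c1NCCN2c1ccc(C#N)cc1C`, which also bears a cyano group, gives 3.5 nM, and that gap lies beyond the usual scatter. Compound 3 `CCCCN(CC)c1nc(C)nc2c1NCCN2c1ccc(C#N)cc1C` has not been measured yet. It is made from compound 1 by one change: cyano in place of methoxy on an aromatic carbon. Within the data shown here, no pair of measured compounds shows exactly this swap on the same core, so the size of the step cannot be read from a measured example. Compound 3 is nonetheless expected to give a somewhat lower number than compound 1, because the cyano-bearing compound 2 gives 3.5 nM. The expected step from compound 1 to compound 3 is a 2.3-fold lower number from compound 1 to compound 3 (0.37 log units; beyond the scatter). Compound 3 is therefore estimated at 5 nM, with a likely range from 1.5 nM to 15 nM.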

Compound 3, half-maximal inhibitory concentration: 102 nM
Compound 3: middle estimate off by 20-fold (1.31 log units), on the low side; the whole stated range lies below it.
By their numbers in this assay, from the lowest: compound 2; then compound 1; then compound 3.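

In this assay, replacing 4-methoxy-2-methylphenyl with 4-cyano-2-methylphenyl gives an 8.7-fold higher number from compound 1 to compound 3 (0.94 log units; beyond the scatter), so on this core cyano does not serve as a stand-in for methoxy at this position. Cyano alone does not set the number: compound 2 gives 3.5 nM and compound 3 gives 102 nM, although these two differ in only one atom of the core, a carbon in compound 2 and a nitrogen in compound 3. No available evidence explains the weaker binding of compound 3.

The compounds shown leave open how methoxy would compare with cyano on the core of compound 2. They also leave open whether another group at this position, such as ethoxy or an amine, would give a number closer to that of compound 1 or compound 3.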